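This account rests on a few compounds, and the source may have more. Where it says the series, first, only, none or still open, it means among the compounds named here.

Three compounds built around a bridged, nitrogen-containing bicyclic core carrying a pyridyl group were tested in an in vitro assay on HEK-293T cells for displacement of a labelled ligand from Neuronal acetylcholine receptor; alpha3/alpha6/beta2/beta3 (Homo sapiens); on this read-out lower numbers stand for stronger inhibition and higher numbers for weaker inhibition. Compound 1 `C1=C(c2cccnc2)C[C@@H]2CNC[C@H]1C2` gives 1 nM. Compound 2 `CN1C[C@@H]2C=C(c3cccnc3)C[C@@H](C2)C1` gives 320 nM. Compound 3 `CC(C)Oc1cncc(C2=CC3CNCC(C2)C3)c1` gives 2.6 nM, the second highest number of the three. Compound 4 `CC(C)Oc1cncc(C2=CC3CC(C2)CN(C)C3)c1` has not yet been measured in this assay.

Compound 2 differs from compound 1 by a single change: methyl in place of hydrogen on an amine nitrogen in a ring. The consequence in this assay is a 320-fold higher number from compound 1 to compound 2 (2.51 log units; beyond the scatter), a large shift. Compound 4 stands in exactly the same relation to compound 3, since the change is methyl in place of hydrogen on an amine nitrogen in a ring, made at a place described in the same words in both pairs, so it is the same change rather than merely one of the same kind. Among the compounds with values here, how the core of compound 3 differs from that of compound 1 is not broken down here; the two values show only that compound 3 has the higher number.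

Within the data shown here, only one earlier instance of this change is available, so the expectation rests on a single precedent. Compound 4 is expected to give 800 nM in this assay because the earlier instance produced a 320-fold higher number from compound 1 to compound 2 (2.51 log units; beyond the scatter). The step from compound 3 to compound 4 is therefore estimated as a 310-fold higher number from compound 3 to compound 4 (2.49 log units; beyond the scatter), with a plausible range for compound 4 from 200 nM to 3000 nM.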

Compound 4, inhibition constant: 690 nM
Compound 4: middle estimate off by 1.2-fold (0.06 log units), on the high side, and the stated range covers the measured number.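

In this assay, methyl in place of hydrogen on an amine nitrogen in a ring again brought a 270-fold higher number from compound 3 to compound 4 (2.42 log units; beyond the scatter) and so repeated on a second core the large loss seen on the first, with the two steps agreeing within the scatter: the same change on two cores in this assay, a 320-fold higher number (2.51 log units; beyond the scatter) from compound 1 to compound 2 and a 270-fold higher number (2.42 log units; beyond the scatter) from compound 3 to compound 4, 1.2-fold (0.08 log units) apart, within the scatter of two such steps. Within this series, then, the size of the step carried over from one core to the other, and the step taken on one core served as a fair guide to the step on the other, even though the two cores start from different values. Within the data shown here, this rests on only two pairs in a single assay, so it does not establish a rule for other cores, and it says nothing about why adding the methyl raises the number so much.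

The compounds shown leave open whether an ethyl group, a longer chain or an acetyl group on that same ring nitrogen would bring a step of similar size, or whether methyl is already enough to produce the whole loss. They also leave open whether the agreement would hold on a core bearing some other substituent on the pyridyl ring, such as a fluorine or an amine.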